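This account rests on a few compounds, and the source may have more. Where it says the series, first, only, none or still open, it means among the compounds named here.

Compound 1 `COc1cc2ncnc(Nc3cccc(Cl)c3)c2cc1OCCCCC(=O)Nc1ccc(S(N)(=O)=O)cc1` and compound 2 `COc1cc2ncnc(Nc3cccc(C)c3)c2cc1OCCCCC(=O)Nc1ccc(S(N)(=O)=O)cc1` share one core and differ in a single spot: methyl in place of chloro on an aromatic carbon. In a functional assay on A549 cells (Homo sapiens) for antiproliferative activity, read by MTT assay, with a stated time of 72 h (on this read-out lower numbers stand for stronger inhibition and higher numbers for weaker inhibition), compound 1 gives 11200 nM, and in this assay compound 2 gives 16000 nM; the step is a 1.4-fold higher number from compound 1 to compound 2 (0.15 log units; within the scatter).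

Compound 3 `NS(=O)(=O)c1ccc(NC(=S)Nc2ccc3ncnc(Nc4cccc(Cl)c4)c3c2)cc1` is built on a different core, and the difference between the two cores is not broken down here. In this assay, going by the values given here, compound 3 reaches only the limit of the measurement, > 40000 nM, so its number is not known, and it is the one compound at the limit of > 40000 nM in this assay, at which 1 of the 3 values shown sits.

Compound 4 `Cc1cccc(Nc2ncnc3ccc(NC(=S)Nc4ccc(S(N)(=O)=O)cc4)cc23)c1` stands to compound 3 as compound 2 stands to compound 1: methyl in place of chloro on an aromatic carbon. The place is the same, so this is the same change on a second core. Its size is expected to be a step that the limit leaves unreadable from compound 3 to compound 4, resting on the measured pair, where a 1.4-fold higher number from compound 1 to compound 2 (0.15 log units; within the scatter) stayed within the scatter. Because compound 3 sits at > 40000 nM, compound 4 is expected most often to reach the limit too, with an estimate of 55000 nM between 20000 nM and 160000 nM.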

Compound 4, half-maximal inhibitory concentration: > 40000 nM
Compound 4 was reported as a limit (the forecaster's own chance of this, stated with the estimate: 75%); the middle value is on the limit's open side.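

Going by these compounds alone, compound 3 and compound 4 are both reported in this assay only as a limit, not as a number, so no step between them can be read: the limit of > 40000 nM in this assay, at which 2 of the 4 values shown sit. The compounds shown leave open how far past the limit each compound lies, and so whether methyl in place of chloro changes anything on this core.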